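This account rests on a few compounds, and the source may have more. Where it says the series, first, only, none or still open, it means among the compounds named here.

Working notes on a urea series built around the core of compound 2 `O=C(Nc1ccc(-n2ncc3ccccc32)cc1)Nc1ccc(Cl)c(C(F)(F)F)c1`. Three members have been measured in a functional assay on MDA-MB-231 cells (Homo sapiens) for cytotoxicity, read by MTT assay, with a stated time of 72 h; on this read-out lower numbers stand for stronger inhibition and higher numbers for weaker inhibition. Compound 1 `O=C(Nc1ccc(-n2ncc3c(Br)cccc32)cc1)Nc1ccc(Cl)c(C(F)(F)F)c1` gives 7700 nM, compound 2 gives 5000 nM, and compound 3 `CNc1cccc2c1cnn2-c1ccc(NC(=O)Nc2ccc(Cl)c(C(F)(F)F)c2)cc1` gives 3600 nM. Compound 2 thus stands second highest of the three numbers; its nearest neighbour is compound 3 and its furthest compound 1, both within the scatter. The steps among these compounds are all small: a 1.5-fold lower number from compound 1 to compound 2 (0.19 log units; within the scatter), a 2.1-fold lower number from compound 1 to compound 3 (0.33 log units; beyond the scatter) and a 1.4-fold lower number from compound 2 to compound 3 (0.14 log units; within the scatter).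

Compound 4 `O=C(Nc1ccc(-n2ncc3cccnc32)cc1)Nc1ccc(Cl)c(C(F)(F)F)c1` is not yet measured. Its change from compound 2 is a group of 9 heavy atoms (6 carbon, 3 nitrogen; one five-membered aromatic ring with 2 hetero atoms, one six-membered aromatic ring with 1 hetero atom) in place of a group of 9 heavy atoms (7 carbon, 2 nitrogen; one five-membered aromatic ring with 2 hetero atoms, one six-membered aromatic ring of carbon only), on an aromatic carbon: a group of 9 heavy atoms (6 carbon, 3 nitrogen) with one six-membered aromatic ring with 1 hetero atom enters in place of one whose six-membered aromatic ring is of carbon only, on an aromatic carbon. For the measured compounds named here, none of the measured steps makes this same exchange; all three vary a substituent on the six-membered ring of the group that leaves, and none moved this assay by more than a modest amount. With only those steps to go on, the expectation in this assay is a step of no change at the digits printed from compound 2 to compound 4 (within the scatter), nothing beyond the scatter. Compound 4 is therefore estimated at 5000 nM, with a range of 2000 nM to 12000 nM.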

Compound 4, half-maximal inhibitory concentration: > 32000 nM
Compound 4: only a limit was reported; the forecaster's own chance of this, stated with the estimate: 5%; middle value at least 6.4-fold (0.80 log units) from the limit.
By their numbers in this assay, from the lowest: compounds 3, 2 and 1 (each within the scatter of the next, the first and the last beyond it). At a limit, above all of these: compound 4.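

Compound 4 is reported only as a limit in this assay: the limit of > 32000 nM in this assay, at which 1 of the 4 values shown sits.

Substituents on the six-membered ring of the group had moved this read-out by no more than a 2.1-fold lower number from compound 1 to compound 3 (0.33 log units; beyond the scatter), whereas changing that ring itself, from one of carbon only to one with 1 hetero atom, gives an at least 6.4-fold higher number from compound 2 to compound 4 (0.80 log units; beyond the scatter). The same change set against the bromo compound gives an at least 4.1-fold higher number from compound 1 to compound 4 (0.61 log units; beyond the scatter). Within these four compounds, then, the make-up of the ring carries more weight at this place, on the aromatic carbon para to a large group, than the substituents tried on it, and compound 4 sits clear of the other three, which all retain a number.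

From the compounds shown here alone, the true size of the step cannot be told from a limit, so how far compound 4 lies beyond the others stays open. Also open, going by these compounds, is whether a methoxy group or a primary amine on the new ring of compound 4, or a ring nitrogen elsewhere in that six-membered ring, would bring the number back into the range of compounds 1, 2 and 3.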